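A few compounds are considered here, and "the series" means these few. Any claim that something is new, unique, unknown or untested is made for them only; others in the source may bear on it.

Measured compounds: compound 1 `Cc1nc(N2CCN(C3CCCC3)CC2)nc2ccc(NC(=O)COc3ccc(Cl)cc3)cc12` gives 150 nM in a functional assay on CHO-K1 cells for antagonist activity at melanin-concentrating hormone receptor 1 (Homo sapiens), read by inositol phosphate accumulation; on this read-out lower numbers stand for stronger inhibition and higher numbers for weaker inhibition; compound 2 `CCN1CCN(c2nc(C)c3cc(NC(=O)COc4ccc(Cl)cc4)ccc3n2)CC1` gives "not determined" (no result reported) in this assay.

Compound 2 therefore stands nowhere on the numbers: only compound 1 anchors the series. Compound 3 `Cc1nc(N2CCC(O)CC2)nc2ccc(NC(=O)COc3ccc(Cl)cc3)cc12` differs from compound 2 by 4-hydroxypiperidin-1-yl in place of 4-ethylpiperazin-1-yl on an aromatic carbon. Going by the values given here, with no value for compound 2, no step can be measured from it, and the change from 4-ethylpiperazin-1-yl to 4-hydroxypiperidin-1-yl is untested here. Compound 3 is expected to sit weaker than compound 1 in this assay, estimated at 1000 nM, with a range of 200 nM to 5000 nM.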

Compound 3, half-maximal inhibitory concentration: 163 nM
Beside the measured number, compound 3's estimate is 6.1-fold (0.79 log units) above it, and the stated range ends above it.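

In this assay, the position between two ring nitrogen atoms accepts 4-hydroxypiperidin-1-yl in place of 4-cyclopentylpiperazin-1-yl with a 1.1-fold higher number from compound 1 to compound 3 (0.04 log units; within the scatter), so two different groups at this place now read alike. The step from compound 2 to compound 3 cannot be read. Nothing available bears on why these two groups read alike. As far as these compounds go, whether a morpholine or a piperidine carrying a carboxylic acid at this place would read the same remains open.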